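This account rests on a few compounds, and the source may have more. Where it says the series, first, only, none or still open, it means among the compounds named here.

Compound 1 `CC(Sc1nc2c(cnn2C)c(=O)n1-c1ccc(CCO)cc1)c1ccccc1`: 360 nM
Compound 2 `Cn1ncc2c(=O)n(-c3ccccc3)c(SCc3cccc(F)c3)cc21`: 240 nM

In an assay on isolated protein for inhibition of aldehyde dehydrogenase 1A1 (Homo sapiens) (on this read-out lower numbers stand for stronger inhibition and higher numbers for weaker inhibition), compound 1 has the highest number of the two measured compounds, yet compound 2 lies within the usual scatter of it, so no order between them can be claimed. Compound 3 `CC(Sc1nc2c(cnn2C)c(=O)n1-c1ccccc1)c1ccccc1` differs from compound 1 by hydrogen in place of 2-hydroxyethyl on an aromatic carbon. Among the compounds with values here, no step between measured compounds exists here to lean on. Since compound 2 also carries a plain phenyl on its own core and gives 240 nM, the step of a 1.1-fold higher number from compound 1 to compound 3 (0.05 log units; within the scatter) is expected to be small, none beyond the scatter. Compound 3 is estimated at 400 nM, in a range from 150 nM to 1100 nM.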

Compound 3, half-maximal inhibitory concentration: 130 nM
Beside the measured number, compound 3's estimate is 3.1-fold (0.49 log units) above it; measured number outside the range, below it.
By their numbers in this assay, from the lowest: compounds 3, 2 and 1 (each within the scatter of the next, the first and the last beyond it).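

In this assay, hydrogen in place of 2-hydroxyethyl on the aromatic carbon para to a large group gives a 2.8-fold lower number from compound 1 to compound 3 (0.44 log units; beyond the scatter) on the shared core. Within the data shown here, this is the first change at a single place in these compounds, and it shows that this position is not indifferent: the 2-hydroxyethyl group is not needed for inhibition here, and the plain phenyl gives the lower number. No measurement on hand explains the difference.

Whether the hydroxyl or the two-carbon chain accounts for the step stays open. So does how a hydroxymethyl, a methoxy, an amine or a carboxylic acid would read at this position.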